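A few compounds are considered here, and "the series" means these few. Any claim that something is new, unique, unknown or untested is made for them only; others in the source may bear on it.

Measured so far in a functional assay on a cell-free system (plasma, Homo sapiens), with a stated time of 3 min; on this read-out higher numbers stand for weaker inhibition and lower numbers for stronger inhibition:

- compound 1 `O=C(NCc1cc(Cl)ccc1-n1cnnn1)[C@@H]1CC=NN1C(=O)[C@H](O)c1ccccc1F` gives 1100 nM in this test
- compound 2 `CC(C)(C)[C@@H](O)C(=O)N1OCC[C@H]1C(=O)NCc1cc(Cl)ccc1-n1cnnn1` gives 1600 nM in this test

These two values lie within the usual scatter of each other, so compound 1 cannot be told apart from compound 2 on these numbers. Going by the values given here, no two measured compounds differ in just one place, so no measured step guides the next move.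

Compound 3 `O=C(NCc1cc(Cl)ccc1-n1cnnn1)[C@@H]1CC=NN1C(=O)[C@H](O)Cc1ccccc1` keeps the core of compound 1 and carries one change, benzyl in place of 2-fluorophenyl on a saturated chain carbon bound to a carbonyl carbon and an oxygen on a saturated carbon. With no data on this change, only a small move toward a higher number, meaning weaker inhibition, is expected in this assay, and a result within the scatter would fit too. The estimated step of a 2.0-fold higher number from compound 1 to compound 3 (0.30 log units; within the scatter) is a rough expectation only. For compound 3 the estimated value is 2200 nM, with an expected range from 600 nM to 8000 nM in this test.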

Compound 3, half-maximal inhibitory concentration: 1400 nM
Estimate against measurement, compound 3: 1.6-fold (0.20 log units) above; the measured number falls inside the stated range.
By their numbers in this assay, from the lowest: compounds 1, 3 and 2 (each within the scatter of the next).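

In this assay, placing benzyl instead of 2-fluorophenyl on the saturated chain carbon bound to a carbonyl carbon and an oxygen on a saturated carbon gives a 1.3-fold higher number from compound 1 to compound 3 (0.10 log units; within the scatter) and so leaves the two compounds indistinguishable. This is the first single change shown at this position, which the two compounds measured before could not provide as a pair. It shows that replacing 2-fluorophenyl with benzyl here produces no readable shift in this assay, although one step at one position cannot show how the position responds to other groups. From the compounds shown here alone, whether an amine, a carboxylic acid or a longer chain such as phenethyl would move the number beyond the scatter stays open. No measured evidence explains why these two values lie so close.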